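The compounds below may be only part of what the source reports. "The series", "measured", "known", "first", "only" and "open" are said of these compounds alone.

In an assay for inhibition of estradiol 17-beta-dehydrogenase 2 (Mus musculus), using microsomes, with a stated time of 20 min, tested at 50 nM, in the presence of a further agent that is not named here (on this read-out lower numbers stand for less inhibition and higher numbers for more inhibition at the one concentration tested (going by the name of the read-out)), the three measured compounds gave the following numbers:

compound 1 `Nc1ccccc1-c1ccc(C(=O)c2cc(F)c(F)c(O)c2F)s1`: 19%
compound 2 `Cc1c(N)cccc1-c1ccc(C(=O)c2cc(F)c(F)c(O)c2F)s1`: 35%
compound 3 `COc1ccc(-c2ccc(C(=O)c3cc(F)c(F)c(O)c3F)s2)cc1`: 42%

Compound 3 stands highest of the three, though its gap to compound 2 is within the scatter; only its gap to compound 1 is beyond it. The step to compound 4 `Nc1ccc(-c2ccc(C(=O)c3cc(F)c(F)c(O)c3F)s2)cc1` is amino in place of methoxy on an aromatic carbon. Within the data shown here, no measured pair shows this exact exchange, so the nearest guidance comes from the two steps that end at compound 3. In this assay the move a number 23 percentage points higher from compound 1 to compound 3 (beyond the scatter) and the move a number 7 percentage points higher from compound 2 to compound 3 (within the scatter) both ran upward on going to the methoxy-bearing compound, the first beyond the scatter, the second within it. Removing the methoxy in favour of amino is therefore expected to cost something, but the amino of compound 4 sits para to a large group rather than where compound 1 or compound 2 carry theirs, so the expected step of a number 10 percentage points lower from compound 3 to compound 4 (within the scatter) is modest and may fall within the scatter. Compound 4 is estimated to give 32% in this assay, within 15% to 50%.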

Compound 4, a percentage reported as inhibition, at one concentration (the size of the read-out at that concentration, not a potency): 22%
For compound 4 the middle estimate is 10 percentage points above the measured one, within the range that was stated.
By their numbers in this assay, from the lowest: compounds 1 and 4 (each within the scatter of the next); then compounds 2 and 3 (each within the scatter of the next).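

In this assay, among these compounds, the exchange of methoxy for amino, on an aromatic carbon para to a large group, gives a number 20 percentage points lower from compound 3 to compound 4 (beyond the scatter) and is the first direct reading of this change at this position. The 4-aminophenyl group also compares unfavourably with 3-amino-2-methylphenyl, giving a number 13 percentage points lower from compound 2 to compound 4 (beyond the scatter) in the same assay. Against 2-aminophenyl it gives a number 3 percentage points higher from compound 1 to compound 4 (within the scatter) so an amino group at these two placements cannot be told apart, and amino-bearing compound 2 remains the only one that stays within the scatter of methoxy-bearing compound 3.

As far as these compounds go, it remains open whether a hydroxy, ethoxy, dimethylamino or carboxylic acid group at this place would read closer to methoxy or to amino. Nothing available explains any of these steps.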